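This account rests on a few compounds, and the source may have more. Where it says the series, first, only, none or still open, it means among the compounds named here.

Compound 1 `O=C1C(Nc2ccc(F)cc2)=CC(=O)c2ncccc21` in a functional assay on the whole organism (aorta) with Rattus norvegicus as the target (a lower number here means a smaller maximal response, a higher number a larger maximal response), gives 79%. Compound 2 `O=C1C(Nc2cccc(F)c2)=CC(=O)c2ncccc21` has the same atoms joined differently; the difference between the two cores is not broken down here. In this assay compound 2 gives 85%, and compound 3 `O=C1C(Nc2cc(F)cc(F)c2)=CC(=O)c2ncccc21` gives 91%. The change from compound 2 to compound 3 is fluoro in place of hydrogen on an aromatic carbon; it made a step of a number 6 percentage points higher from compound 2 to compound 3 (within the scatter).

Compound 4 `O=C1C(Nc2ccc(F)cc2F)=CC(=O)c2ncccc21` awaits measurement. From compound 1 it differs by fluoro in place of hydrogen on an aromatic carbon, the same kind of change, though the entering fluoro here is ortho to a large group and meta to a fluoro group, whereas in compound 3 it is meta to a fluoro group and meta to a large group. For compound 4 the expected step is a number 6 percentage points higher from compound 1 to compound 4 (within the scatter), expected because of the like step a number 6 percentage points higher from compound 2 to compound 3 (within the scatter). Compound 4 is therefore estimated at 85% in this assay, likely between 74% and 96%.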

Compound 4, largest response reached (Emax), in percent of the reference or control that the assay uses: 94%
For compound 4 the middle estimate is 9 percentage points below the measured one; the range from low to high includes it.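

In this assay, fluoro in place of hydrogen on an aromatic carbon gives a number 15 percentage points higher from compound 1 to compound 4 (beyond the scatter). The two steps for this change do not differ by more than repeated measurements allow, so the data give no sign that the change behaves differently on the two cores: the same change on two cores in this assay, a number 6 percentage points higher (within the scatter) from compound 2 to compound 3 and a number 15 percentage points higher (beyond the scatter) from compound 1 to compound 4, 9 percentage points apart, within the scatter of two such steps. This rests on a single pair for each core, with the entering fluoro in different surroundings, so it does not show that the step keeps one size across the series.

Open, going by these compounds, is whether chloro, methoxy or trifluoromethyl in place of the same hydrogen would give a like step. Also open, on these data alone, is what an amine or a carboxylic acid on that ring would do to the response.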